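A few compounds are considered here, and "the series" means these few. Any claim that something is new, unique, unknown or untested is made for them only; others in the source may bear on it.

Measured in a functional assay on A549 cells (Homo sapiens) for inhibition, read by ELISA, with a stated time of 24 h; on this read-out higher numbers stand for weaker inhibition of growth and lower numbers for stronger inhibition of growth:
- Compound 1 `CN1CCN(C(=O)ONC(=O)/C=C/c2ccccc2OC(=O)c2ccccc2)CC1`: > 100000 nM (a limit of the assay, not a number)
- Compound 2 `CC(=O)ONC(=O)/C=C/c1ccccc1OC(=O)c1ccccc1`: 30200 nM
- Compound 3 `CN1CCN(C(=O)/C=C/c2ccccc2OC(=O)c2ccccc2)CC1`: > 100000 nM (a limit of the assay, not a number)

For the measured compounds named here, compound 2 is the only compound with a true number. The other two readings are the limit of > 100000 nM in this assay, at which 2 of the 3 values shown sit.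

Compound 4 `O=C(/C=C/c1ccccc1OC(=O)c1ccccc1)NOC(=O)c1ccccc1` is the next one to read against compound 2. The change is phenyl in place of methyl on a carbonyl carbon, so acetoxy becomes benzoyloxy.

Going by the values given here, two measured steps bear on this, and both are at least modest. The first is an at least 3.3-fold lower number from compound 1 to compound 2 (0.51 log units; beyond the scatter), with methyl in place of 4-methylpiperazin-1-yl on a carbonyl carbon. The second is an at least 3.3-fold higher number from compound 2 to compound 3 (0.51 log units; beyond the scatter), with 4-methylpiperazin-1-yl in place of acetoxyamino on a carbonyl carbon. As far as these compounds go, each has a limit at one end, so its true size remains open. Neither step tests phenyl at this place, and neither gives a direction for the change to benzoyloxy.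

The expected result is therefore no shift beyond the scatter, though with wide uncertainty. The expected step is a 1.1-fold lower number from compound 2 to compound 4 (0.03 log units; within the scatter). For compound 4 the estimated value is 28000 nM, with an expected range from 9000 nM to 90000 nM.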

Compound 4, concentration for 50% growth inhibition: 8800 nM
For compound 4 the middle estimate is 3.2-fold (0.50 log units) above the measured one, outside the stated range (below it).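

Notes on the acyl place: in this assay, replacing methyl with phenyl on this carbonyl carbon, so that acetoxy becomes benzoyloxy, gives a step beyond the scatter (a 3.4-fold lower number from compound 2 to compound 4 (0.54 log units; beyond the scatter)). For the compounds shown here, this is the first step with a true number at both ends, so it gives this place a direction that the earlier steps, each with a limit at one end, could not give: within this pair, phenyl goes with the lower number and thus stronger inhibition of growth. Against 4-methylpiperazin-1-yl on the same carbonyl carbon, the gap is large (an at least 11-fold lower number from compound 1 to compound 4 (1.05 log units; beyond the scatter)), but the value for compound 1 is a limit of the assay, so this step has only a minimum size: the limit of > 100000 nM in this assay, at which 2 of the 4 values shown sit.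

The compounds shown rest on one pair with a true number at both ends, so they do not separate the aromatic ring from the larger carbon count of phenyl; a cyclohexyl group or a longer chain such as propyl at this place would address that. They also leave open how a substituted phenyl, such as 4-methoxyphenyl or 4-chlorophenyl, or a pyridine ring would read here.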